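Methoxy to chloro on the oxime-bearing core

A few compounds are considered here, and "the series" means these few. Any claim that something is new, unique, unknown or untested is made for them only; others in the source may bear on it.

Measured compounds:
compound 1, `COc1ccc(C(=O)CSc2nc3[nH]c(=O)n(C)c(=O)c3[nH]2)cc1`, in a functional assay on A549 cells (Homo sapiens) for inhibition, read by MTT assay, with a stated time of 48 h (on this read-out higher numbers stand for weaker inhibition and lower numbers for stronger inhibition), compound 1 gives 6100 nM
compound 2, `Cn1c(=O)[nH]c2nc(SCC(=O)c3ccc(Cl)cc3)[nH]c2c1=O`, in this assay compound 2 gives 8100 nM
compound 3, `COc1ccc(/C(CSc2nc3c([nH]2)c(=O)n(C)c(=O)n3C)=N\O)cc1`, in this assay compound 3 gives 1500 nM

Compound 1 and compound 2 share the ketone-bearing core and differ in one place: chloro in place of methoxy on an aromatic carbon. The step is a 1.3-fold higher number from compound 1 to compound 2 (0.12 log units; within the scatter), so the two values stand together and nothing can be read into their order.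

Compound 3 carries the oxime-bearing core with a methoxy group on the phenyl ring. Its value is the lowest of the three, and the gap to compound 1 and to compound 2 lies beyond the scatter. The difference between the two cores is not broken down here.

Compound 4, `Cn1c(=O)c2[nH]c(SC/C(=N/O)c3ccc(Cl)cc3)nc2n(C)c1=O`, has not been measured. It differs from compound 3 by chloro in place of methoxy on an aromatic carbon, the same change as from compound 1 to compound 2, made at a place described in the same words. Among the measured compounds shown here, the only precedent is the single step from compound 1 to compound 2, which stayed within the scatter, so in this assay the step from compound 3 to compound 4 is expected to be about as small, a 1.3-fold higher number from compound 3 to compound 4 (0.10 log units; within the scatter). For the measured compounds named here, compound 4 is therefore expected to give 1900 nM in this assay, with a range from 900 nM to 4500 nM, the width reflecting that one step on a different core is the only guide.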

Compound 4, half-maximal inhibitory concentration: 1500 nM
Compound 4: middle estimate off by 1.3-fold (0.10 log units), on the high side; the range from low to high includes it.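

In this assay the change from 4-methoxyphenyl to 4-chlorophenyl on the oxime-bearing core gives no change at the digits printed from compound 3 to compound 4 (within the scatter), and set beside the step on the ketone-bearing core, the change shows no detectable difference between the two cores: the same change on two cores in this assay, a 1.3-fold higher number (0.12 log units; within the scatter) from compound 1 to compound 2 and no change at the digits printed (within the scatter) from compound 3 to compound 4, 1.3-fold (0.12 log units) apart, within the scatter of two such steps

Within this small set, then, methoxy and chloro at this place can be treated as interchangeable on either core, and the result on one core was a fair guide to the result on the other. This does not show that the two groups are equivalent in general or that any change carries from one core to another, since both steps are small, the comparison rests on a single pair of steps in one cell line, and a small step carrying over says little about whether a large one would.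

The compounds shown leave open whether groups of other kinds on the same aromatic carbon, such as an amine, a carboxylic acid or a nitrile, would also give matching steps on the two cores. They also leave open whether the match would survive a longer chain in place of the one joining the sulfur to the aromatic ring.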